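From a Pentyl to a Benzyl Chain

The compounds below may be only part of what the source reports. "The series", "measured", "known", "first", "only" and "open" are said of these compounds alone.

Compound 1 `CCCCOc1ccccc1-c1ncc(C(=O)OCC)c(=O)[nH]1`: 0.5 mg/kg
Compound 2 `CCOC(=O)c1cnc(-c2ccccc2OCC(C)C)[nH]c1=O`: 3 mg/kg
Compound 3 `CCCCCOc1ccccc1-c1ncc(C(=O)OCC)c(=O)[nH]1`: 2 mg/kg

These values come from a functional assay on the whole organism (strain Sprague-Dawley) for inhibition, with Rattus norvegicus as the target, with a stated time of 10 min; on this read-out higher numbers stand for an effect only at larger amounts of compound and lower numbers for an effect already at smaller amounts. Compound 3 lies within the scatter of compound 2, and both need clearly larger doses than compound 1. Compound 4 `CCOC(=O)c1cnc(-c2ccccc2OCc2ccccc2)[nH]c1=O` differs from compound 3 by phenyl in place of butyl on a saturated chain carbon bound to an oxygen on an aromatic ring. The closest evidence comes from changes at this same carbon: a 6.0-fold higher number from compound 1 to compound 2 (0.78 log units; beyond the scatter), and a 1.5-fold lower number from compound 2 to compound 3 (0.18 log units; within the scatter). Neither replaces a chain with a ring, so the direction remains uncertain. The expected change is small, an estimated 1.5-fold higher number from compound 3 to compound 4 (0.18 log units; within the scatter). Compound 4 is expected at about 3 mg/kg, with an estimated range of 0.8 mg/kg to 10 mg/kg.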

Compound 4, dose for 50% inhibition: > 5 mg/kg
Compound 4 was reported as a limit; the forecaster's own chance of this, stated with the estimate: 5%; at least 1.6-fold (0.22 log units) between middle value and limit.
By their numbers in this assay, from the lowest: compound 1; then compounds 3 and 2 (each within the scatter of the next). At a limit, above all of these: compound 4.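

Among these compounds, compound 4 puts a ring on this carbon, where the earlier compounds carry only chains, and it is reported only as a limit: the limit of > 5 mg/kg in this assay, at which 1 of the 4 values shown sits. Replacing pentyloxy with benzyloxy gives an at least 2.5-fold higher number from compound 3 to compound 4 (0.39 log units; beyond the scatter), and the widest gap is an at least 10-fold higher number from compound 1 to compound 4 (1.00 log units; beyond the scatter), so this ring brings no gain in dose over the chains. The remaining step, an at least 1.6-fold higher number from compound 2 to compound 4 (0.22 log units; that floor lies within the scatter), does not separate the ring from the branched chain. Still open, going by these compounds, is whether a phenethyl group, or a benzyl group carrying an amine, would come closer to compound 1.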